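The source may report more compounds than this note shows. Statements on the series, on what has been measured and on what is new or still open speak of the compounds shown alone.

In an in vitro ADME assay on microsomes from liver (Simiiformes) (a lower number here means that the compound disappears faster, a higher number that the compound lasts longer), compound 1 `COc1nc(-c2cc(C)c(OCCCc3cc(C)no3)c(C)c2)no1` gives 0.55 h and compound 2 `Cc1cc(CCCOc2c(C)cc(-c3noc(C4CC4)n3)cc2C)on1` gives 2.23 h, the higher of the two numbers and beyond the scatter. Compound 3 `Cc1cc(CCCOc2c(C)cc(-c3noc(C(C)(F)F)n3)cc2C)on1` differs from compound 2 by one change: 1,1-difluoroethyl in place of cyclopropyl on an aromatic carbon. Going by the values given here, one measured step bears on this site, a 4.1-fold higher number from compound 1 to compound 2 (0.61 log units; beyond the scatter), a modest move that put cyclopropyl in place of methoxy. It says nothing directly about 1,1-difluoroethyl, so no step beyond the scatter is expected. The expected step is a 1.1-fold higher number from compound 2 to compound 3 (0.05 log units; within the scatter). For compound 3 the estimate is 2.5 h, with an expected range from 1.1 h to 5.5 h.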

Compound 3, half-life: 1.1 h
Estimate against measurement, compound 3: 2.3-fold (0.36 log units) above, within the range that was stated.
By their numbers in this assay, from the lowest: compounds 1 and 3 (each within the scatter of the next); then compound 2.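

Swapping cyclopropyl for 1,1-difluoroethyl on this carbon of the five-membered aromatic ring gives a 2.0-fold lower number from compound 2 to compound 3 (0.31 log units; beyond the scatter) in this assay and so does not preserve the longer half-life. Replacing methoxy with 1,1-difluoroethyl gives a 2.0-fold higher number from compound 1 to compound 3 (0.30 log units; within the scatter) and leaves compound 3 indistinguishable from compound 1, so among these three groups only cyclopropyl stands clear of the others. Nothing measured here explains this difference.

From the compounds shown here alone, whether cyclobutyl, isopropyl or an amine at this position would match cyclopropyl remains open.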